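The compounds below may be only part of what the source reports. "The series", "measured", "known", "first", "only" and "open" are said of these compounds alone.

Among the measured compounds shown here, compound 3 `CN1CCN(c2nc(-c3ccc(Cl)c(Cl)c3)nc3c2ncn3C)CC1` is one of three compounds measured in an assay on cells for displacement of a labelled ligand from adenosine receptor A2b (Homo sapiens), read by scintillation counting and radioligand binding, with a stated time of 30 min, tested at 10 uM; on this read-out higher numbers stand for more inhibition at the one concentration tested (going by the name of the read-out) and lower numbers for less inhibition. In this assay compound 3 gives 28.3%, the second highest of the three numbers. Its nearest neighbour is compound 2 `CN1CCN(c2nc(-c3ccc(Cl)c(Cl)c3)nc3[nH]cnc23)CC1`, which gives 24.1%; the step of a number 4.2 percentage points higher from compound 2 to compound 3 (within the scatter) is within the scatter. Farthest from it is compound 1 `CN1CCN(c2nc(-c3cccc(O)c3)nc3c2ncn3C)CC1`, which gives 47.8%; the step of a number 19.5 percentage points lower from compound 1 to compound 3 (beyond the scatter) is modest but beyond the scatter.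

Compound 4 `CN1CCN(c2nc(-c3cccc(Cl)c3)nc3c2ncn3C)CC1` has not yet been measured. It differs from compound 3 in one place: hydrogen in place of chloro on an aromatic carbon. For the measured compounds named here, the only measured step that touches this part of the molecule is a number 19.5 percentage points lower from compound 1 to compound 3 (beyond the scatter), where the 3,4-dichlorophenyl group came with a lower number than 3-hydroxyphenyl. The step of a number 4.2 percentage points higher from compound 2 to compound 3 (within the scatter) concerns the aromatic nitrogen and does not bear on this change. Loss of one chloro from the 3,4-dichlorophenyl group gives 3-chlorophenyl, which lies between the two aryl groups already measured, so one would expect at most a small rise, a number 6.7 percentage points higher from compound 3 to compound 4 (within the scatter), and quite possibly none beyond the scatter. Compound 4 is therefore estimated to give 35% in this assay, within a range of 15% to 55%.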

Compound 4, a percentage reported as inhibition, at one concentration (the size of the read-out at that concentration, not a potency): 19.2%
The estimate for compound 4 lay 15.8 percentage points above the measured number; the range from low to high includes it.
By their numbers in this assay, from the lowest: compounds 4, 2 and 3 (each within the scatter of the next); then compound 1.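

Taking away the chloro ortho to a chloro group and para to a large group leaves the number within the scatter (a number 9.1 percentage points lower from compound 3 to compound 4 (within the scatter)) in this assay, so the 3,4-dichlorophenyl and 3-chlorophenyl groups cannot be told apart on this read-out. The earlier step from compound 1 to compound 3 changed the hydroxy group and added a chloro at once, whereas the step of a number 28.6 percentage points lower from compound 1 to compound 4 (beyond the scatter) is a single exchange of hydroxy for chloro, and it alone lies beyond the scatter, so among these compounds the fall goes with the loss of the hydroxy group rather than with the added chloro. No measurement offered here accounts for either step.

The compounds shown leave open how an amine or a methoxy group on that aromatic carbon would compare with the hydroxy group of compound 1. They also leave open whether the methyl on the aromatic nitrogen would stay without visible effect alongside the 3-hydroxyphenyl group, as that step is known only with the 3,4-dichlorophenyl group.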